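Aryl variation at the saturated ring carbon: compound 4

This account rests on a few compounds, and the source may have more. Where it says the series, first, only, none or still open, it means among the compounds named here.

Measured in a functional assay on Ehrlich cells (Mus musculus) for cytotoxicity, tested at 50 ug/mL (on this read-out higher numbers stand for a stronger effect at the one concentration tested and lower numbers for a weaker effect), so far:
compound 1 `COc1cc(N2C(N)=C(C#N)C(c3ccc(OC)c4ccccc34)C3=C2CC(C)(C)CC3=O)cc(OC)c1OC` gives 40%
compound 2 `COc1cc(N2C(N)=C(C#N)C(c3ccc(Cl)cc3Cl)C3=C2CC(C)(C)CC3=O)cc(OC)c1OC` gives 95%
compound 3 `COc1cc(N2C(N)=C(C#N)C(c3cccc([N+](=O)[O-])c3)C3=C2CC(C)(C)CC3=O)cc(OC)c1OC` gives 30%

Compound 3 holds the lowest of the three numbers. Its nearest neighbour is compound 1, since a number 10 percentage points lower from compound 1 to compound 3 (within the scatter); its furthest is compound 2, since a number 65 percentage points lower from compound 2 to compound 3 (beyond the scatter).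

The next change is hydrogen in place of nitro on an aromatic carbon, giving compound 4 `COc1cc(N2C(N)=C(C#N)C(c3ccccc3)C3=C2CC(C)(C)CC3=O)cc(OC)c1OC`. For the measured compounds named here, no measured step removes a nitro group; all three steps swap the whole aryl group. Of these, a number 55 percentage points higher from compound 1 to compound 2 (beyond the scatter) and a number 65 percentage points lower from compound 2 to compound 3 (beyond the scatter) show that the aryl group at this carbon can move the number widely, whereas a number 10 percentage points lower from compound 1 to compound 3 (within the scatter) did not. The bearing on compound 4 is therefore indirect and the direction is open. The step of a number 10 percentage points higher from compound 3 to compound 4 (within the scatter) is expected, not clearly beyond the scatter. Compound 4 is estimated at 40%, within 15% to 80%.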

Compound 4, a percentage reported as activity, at one concentration (the size of the read-out at that concentration, not a potency): 8%
Beside the measured number, compound 4's estimate is 32 percentage points above it, outside the stated range (below it).
By their numbers in this assay, from the lowest: compound 4; then compounds 3 and 1 (each within the scatter of the next); then compound 2.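

In this assay the unsubstituted phenyl ring is no neutral baseline at this position, since each substituted aryl group shown sits higher (a number 22 percentage points lower from compound 3 to compound 4 (beyond the scatter); a number 32 percentage points lower from compound 1 to compound 4 (beyond the scatter); a number 87 percentage points lower from compound 2 to compound 4 (beyond the scatter)). The nitro group alone, changed at a single aromatic carbon, accounts for a step beyond the scatter, which the earlier whole-aryl swaps could not isolate.

Going by these compounds, whether an amine or a carboxylic acid at that aromatic carbon would also raise the number remains open. How much of the high number of compound 2 rests on either chlorine alone is also unresolved. No measurement available here offers an explanation for these steps.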